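Swapping an Aromatic Group for Tert-Butyl on the Amine

The source may report more compounds than this note shows. Statements on the series, on what has been measured and on what is new or still open speak of the compounds shown alone.

In a functional assay (aorta) with Rattus norvegicus as the target (on this read-out lower numbers stand for stronger inhibition and higher numbers for weaker inhibition), compound 1 (`COc1ccc(NCCCOc2ccc(S(=O)(=O)c3c(C(C)C)cn4ccccc34)cc2)cc1OC`) gives 396 nM. For the measured compounds named here, that is the higher of the two numbers known so far: compound 2 (`CCCCN(CCCC)CCCOc1ccc(S(=O)(=O)c2c(CC)cn3ccccc23)cc1`) gives 31.3 nM, and the gap lies beyond the usual scatter of repeated measurements. Compound 3 (`CC(C)c1cn2ccccc2c1S(=O)(=O)c1ccc(OCCCNC(C)(C)C)cc1`) has not yet been measured. It keeps the rest of compound 1 but carries tert-butyl in place of 3,4-dimethoxyphenyl on an amine nitrogen. Going by the values given here, no measured pair shows this change on its own, so any forecast is a judgment. Compound 2 at 31.3 nM shows that much lower numbers do occur in this assay, so a downward move beyond the scatter is expected rather than no change. The estimated size of the move is a 5.0-fold lower number from compound 1 to compound 3 (0.69 log units; beyond the scatter). For compound 3 the expected value is 80 nM, within an estimated range of 20 nM to 320 nM.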

Compound 3, half-maximal inhibitory concentration: 41.8 nM
Estimate against measurement, compound 3: 1.9-fold (0.28 log units) above, within the range that was stated.
By their numbers in this assay, from the lowest: compounds 2 and 3 (each within the scatter of the next); then compound 1.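

In this assay, for the compounds shown here, the first step that changes only the group on this amine nitrogen is a 9.5-fold lower number from compound 1 to compound 3 (0.98 log units; beyond the scatter), with tert-butyl in place of 3,4-dimethoxyphenyl. Going by these compounds alone, the group at this position therefore has a clear effect on the read-out, something the earlier compounds could not show because they differed in more than one place. An aromatic ring on this nitrogen is also not needed for a low number, and no measurement shown here explains the step.

This single step cannot separate the loss of the ring from the loss of the two methoxy groups, and an unsubstituted phenyl group on the same nitrogen would tell these apart. It also leaves open how a cyclohexyl group or a straight n-butyl chain would compare with tert-butyl at this position.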